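The compounds below may be only part of what the source reports. "The series", "measured", "known", "first", "only" and "open" are said of these compounds alone.

Three compounds of this series share one core and differ in their substituents. Compound 1 `COc1ccc(S(=O)(=O)N2CCN(Cc3ccccc3)CC2)cc1S(=O)(=O)N1CCN(Cc2ccccc2)CC1` carries a methoxy group and benzyl substituents; in an ADME assay on L929 cells (Mus musculus) for cytotoxicity, read by CCK-8 assay, with a stated time of 48 h, tested at 10 uM (a higher number here means a weaker effect of the compound at the concentration tested, a lower number a stronger effect), compound 1 gives 55.6%. Compound 2 `CCOc1ccc(S(=O)(=O)N2CCN(c3cccc(C)c3)CC2)cc1S(=O)(=O)N1CCN(c2cccc(C)c2)CC1` carries an ethoxy group and methylphenyl substituents, and in this assay compound 2 gives 56.6%. Compound 3 `CCOc1ccc(S(=O)(=O)N2CCN(c3ccccc3F)CC2)cc1S(=O)(=O)N1CCN(c2ccccc2F)CC1` carries an ethoxy group and fluorophenyl substituents, and in this assay compound 3 gives 70.4%, the highest of the three numbers, with a gap beyond the scatter to compound 2 and a slightly wider gap, also beyond the scatter, to compound 1.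

Compound 4 `COc1ccc(S(=O)(=O)N2CCN(c3ccccc3F)CC2)cc1S(=O)(=O)N1CCN(c2ccccc2F)CC1` differs from compound 3 in one place: hydrogen in place of methyl on a saturated chain carbon bound to an oxygen on an aromatic ring. Among the measured compounds shown here, no pair of measured compounds differs by this change alone, so its effect on the read-out is not known from the data at hand. Compound 1 and compound 2 differ in this place but also in their other substituents, and their numbers lie within the scatter of each other, which gives no sign of a large shift. The step is therefore expected to be small, a number 4.4 percentage points lower from compound 3 to compound 4 (within the scatter), within the usual scatter, downward if anything. Compound 4 is expected to give 66% in this assay, with a range from 52% to 80%.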

Compound 4, a percentage reported as activity, at one concentration (the size of the read-out at that concentration, not a potency): 77.8%
The estimate for compound 4 lay 11.8 percentage points below the measured number; the range from low to high includes it.
By their numbers in this assay, from the lowest: compounds 1 and 2 (each within the scatter of the next); then compounds 3 and 4 (each within the scatter of the next).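

Among the compounds shown here, compounds 3 and 4 form the first pair that isolates this change, with the fluorophenyl substituents held constant, so the exchange of methyl for hydrogen on a saturated chain carbon bound to an oxygen on an aromatic ring, ethoxy to methoxy, can now be read directly. In this assay it is a number 7.4 percentage points higher from compound 3 to compound 4 (within the scatter). In this pair, then, the loss of that one carbon does not move the read-out beyond the usual scatter, and nothing measured here offers an explanation for the size of the step.

This single pair leaves open whether the same holds with the benzyl or methylphenyl substituents, since neither is seen with both the ethoxy and the methoxy group. It also cannot show how the read-out would respond at this place to a longer chain such as propoxy, to a branched chain such as isopropoxy, or to a terminal amine or carboxylic acid on the chain.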